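Replacing the Anilino Arm with a Pyrrolidinyl Ether

The compounds below may be only part of what the source reports. "The series", "measured", "known", "first", "only" and "open" are said of these compounds alone.

Of the compounds shown here, three built on one shared core have been measured in a functional assay on K562 cells (Homo sapiens) for antiproliferative activity, read by CellTiter-Glo and CCK-8 assay, with a stated time of 72 h; a higher number here means a weaker inhibitor of growth, a lower number a stronger inhibitor of growth. Compound 1 `Cc1ccc(NC(=O)c2cccc(C(F)(F)F)c2)cc1N1Cc2cnc(Nc3ccc(C)c(C(F)(F)F)c3)nc2N(C)C1=O` gives 29 nM. Compound 2 `CNc1cc(Nc2ncc3c(n2)N(C)C(=O)N(c2cc(NC(=O)c4cccc(C(F)(F)F)c4)ccc2C)C3)ccc1C` gives 19 nM, and the step of a 1.5-fold lower number from compound 1 to compound 2 (0.18 log units; within the scatter) stays within the scatter. Compound 3 `Cc1ccc(Nc2ncc3c(n2)N(C)C(=O)N(c2cc(NC(=O)c4cccc(C(F)(F)F)c4)ccc2C)C3)cc1N` gives 3 nM, the lowest of the three numbers; the steps of a 9.7-fold lower number from compound 1 to compound 3 (0.99 log units; beyond the scatter) and a 6.3-fold lower number from compound 2 to compound 3 (0.80 log units; beyond the scatter) both lie beyond the scatter, so compound 3 is the strongest inhibitor of growth among the three.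

Compound 4 `Cc1ccc(NC(=O)c2cccc(C(F)(F)F)c2)cc1N1Cc2cnc(O[C@H]3CCNC3)nc2N(C)C1=O` differs from compound 3 by (pyrrolidin-3-yl)oxy in place of (3-amino-4-methylphenyl)amino on an aromatic carbon. For the measured compounds named here, no measured step removes this whole aryl group; the steps seen so far only alter the substituent on that ring, and even those shift this assay by as much as a 9.7-fold lower number from compound 1 to compound 3 (0.99 log units; beyond the scatter). Exchanging the entire group for a small saturated ether is a larger change, so a weaker inhibitor of growth is expected, with a step of a 100-fold higher number from compound 3 to compound 4 (2.00 log units; beyond the scatter). Compound 4 is therefore estimated at 300 nM, within a range of 30 nM to 3000 nM.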

Compound 4, concentration for 50% growth inhibition: 450 nM
For compound 4 the middle estimate is 1.5-fold (0.18 log units) below the measured one; the measured number falls inside the stated range.
By their numbers in this assay, from the lowest: compound 3; then compounds 2 and 1 (each within the scatter of the next); then compound 4.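

Changing a substituent on the aryl ring moved this assay far less than removing the whole (3-amino-4-methylphenyl)amino arm, which gives a 150-fold higher number from compound 3 to compound 4 (2.18 log units; beyond the scatter). The loss does not depend on which aryl arm is the reference, as the other two comparisons also give large steps: a 24-fold higher number from compound 2 to compound 4 (1.37 log units; beyond the scatter) and a 16-fold higher number from compound 1 to compound 4 (1.19 log units; beyond the scatter). Compound 4 is thus the weakest inhibitor of growth of the four, and no measurement shown here accounts for the size of this loss.

On these data alone, this single change replaces the aromatic ring with a saturated one and the linking nitrogen with oxygen, so the contribution of each remains unknown. A phenoxy group, which would keep the aromatic ring with the oxygen link, or a (pyrrolidin-3-yl)amino group, which would keep the saturated ring with a nitrogen link, could help separate the two.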